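Arylthiomethyl Purine Ribosides: Transporter Binding Notes

The compounds below may be only part of what the source reports. "The series", "measured", "known", "first", "only" and "open" are said of these compounds alone.

Measured so far:
compound 1 `OC[C@H]1O[C@@H](n2cnc3c(OCc4ccccc4)ncnc32)[C@H](O)[C@@H]1O`: 2090 nM in an assay on isolated protein for binding affinity to Equilibrative nucleoside transporter 1 (Homo sapiens); a lower number here means a stronger inhibitor, a higher number a weaker inhibitor
compound 2 `OC[C@H]1O[C@@H](n2cnc3c(CSc4c(F)cccc4Cl)ncnc32)[C@H](O)[C@@H]1O`: 1510 nM in this assay

Compound 2 holds the lower of the two numbers in this assay; the gap to compound 1 is within the scatter, so the two stand together rather than in an order. Among the measured compounds shown here, only two compounds have been measured, and no pairwise step between them is available.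

Compound 3 `OC[C@H]1O[C@@H](n2cnc3c(CSc4cccc(I)c4)ncnc32)[C@H](O)[C@@H]1O` is the next compound. It differs from compound 2 in one place: 3-iodophenyl in place of 2-chloro-6-fluorophenyl on a sulfur. For the measured compounds named here, no measured step in this assay speaks to a change of this kind, so the direction cannot be drawn from the series itself. The expectation is a step that stays near or within the scatter, with no clear direction favoured: from compound 2 to compound 3 the estimated shift is a 1.2-fold lower number from compound 2 to compound 3 (0.07 log units; within the scatter). For compound 3 the expected value in this assay is 1300 nM, estimated range 400 nM to 4000 nM.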

Compound 3, half-maximal inhibitory concentration: 245 nM
Compound 3: the middle estimate sits 5.3-fold (0.72 log units) above what was measured; measured number outside the range, below it.
By their numbers in this assay, from the lowest: compound 3; then compounds 2 and 1 (each within the scatter of the next).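

The aryl group on the sulfur is not indifferent in this assay: 3-iodophenyl in place of 2-chloro-6-fluorophenyl gives a 6.2-fold lower number from compound 2 to compound 3 (0.79 log units; beyond the scatter) and so moves the number beyond the scatter, which the earlier pair did not do. Compound 3 also separates from the compound with the group of 8 heavy atoms on the aromatic carbon, with an 8.5-fold lower number from compound 1 to compound 3 (0.93 log units; beyond the scatter) as the larger step, and it now holds the lowest number of the three. No measurement at hand accounts for either step.

The change to compound 3 alters the identity, number and placement of the halogens at once, so their contributions remain unseparated. An unsubstituted phenyl, a 3-chlorophenyl or a 3-bromophenyl on the same sulfur would show how much of the step belongs to the iodine.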